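A Second Fluoro on Compound 1

The compounds below may be only part of what the source reports. "The series", "measured", "known", "first", "only" and "open" are said of these compounds alone.

In an ADME assay on microsomes from liver (Mus musculus) for metabolic stability, read by LC-MS, with a stated time of 30 min, tested at 1 uM (a higher number here means that more of the compound is left, a lower number that less of the compound is left), compound 1 (`O=C(NCc1ccc(S(=O)(=O)c2cccc(F)c2)cc1)c1cc2cnccc2[nH]1`) gives 44% and compound 2 (`O=C(NCc1ccc(S(=O)(=O)c2ccccc2)cc1)c1c[nH]c2ccncc12`) gives 45% of the starting amount. These two numbers lie within the usual scatter of each other, so compound 1 stands level with compound 2 and neither can be ranked above the other.

Compound 3 (`O=C(NCc1ccc(S(=O)(=O)c2ccc(F)c(F)c2)cc1)c1cc2cnccc2[nH]1`) differs from compound 1 in one place, where 3-fluorophenyl becomes 3,4-difluorophenyl (fluoro in place of hydrogen on an aromatic carbon). The fluoro takes the place of hydrogen on an aromatic carbon, ortho to a fluoro group and para to a large group.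

Among the measured compounds shown here, no measured pair here shows what this change does, so no step beyond the scatter is expected in this assay for now. The estimated step (a number 2 percentage points higher from compound 1 to compound 3 (within the scatter)) is therefore small. Compound 3 is expected at 46% with a likely range of 30% to 62% in this measurement.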

Compound 3, percent of the compound remaining: 58%
Compound 3: middle estimate off by 12 percentage points, on the low side; measured number inside the range.
By their numbers in this assay, from the lowest: compounds 1 and 2 (each within the scatter of the next); then compound 3.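

In this assay the change from 3-fluorophenyl to 3,4-difluorophenyl, one fluoro in place of hydrogen on an aromatic carbon, gives a number 14 percentage points higher from compound 1 to compound 3 (beyond the scatter) and so shows that this position can affect how much compound is left. Compound 1 and compound 2 differ in more than one place and stand level, so they could say nothing about this carbon, whereas this pair isolates it. Nothing measured here explains why the added fluoro has this effect.

From the compounds shown here alone, it remains open whether a chloro, a methoxy or a nitrile on the same carbon would give a similar step, and whether a fluoro there would do so without the fluoro already on the ring. This single pair also leaves open whether the step carries over to the core of compound 2.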